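Methyl on the ring nitrogen of compound 2

A few compounds are considered here, and "the series" means these few. Any claim that something is new, unique, unknown or untested is made for them only; others in the source may bear on it.

Three amides have been measured: compound 1 (`CCCCCCCCCCCCCCCCNC(=O)[C@@H]1CSC(c2ccc(OC)c(OC)c2)N1`), compound 2 (`CCCCCCCCCCCCCCCCNC(=O)[C@@H]1CSC(c2ccc(NC(C)=O)cc2)N1`) and compound 3 (`CCCCCCCCC/C=C/CCCCCCCNC(=O)[C@@H]1CSC(c2ccc(NC(C)=O)cc2)N1`). In a functional assay on cells (Homo sapiens) for antiproliferative activity, read by sulforhodamine B assay, with a stated time of 48 h (a lower number here means a stronger inhibitor, a higher number a weaker inhibitor), compound 1 gives 1500 nM, compound 2 gives 2100 nM and compound 3 gives 3300 nM. Compound 2 sits with both of its measured neighbours within the scatter: a 1.4-fold higher number from compound 1 to compound 2 (0.15 log units; within the scatter) for the change of aryl group, and a 1.6-fold higher number from compound 2 to compound 3 (0.20 log units; within the scatter) for the change in the chain.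

Compound 4 (`CCCCCCCCCCCCCCCCNC(=O)[C@@H]1CSC(c2ccc(NC(C)=O)cc2)N1C`) differs from compound 2 by methyl in place of hydrogen on an amine nitrogen in a ring. This is methyl in place of hydrogen on an amine nitrogen in a ring, next to the ring atom that bears a 4-acetamidophenyl group.

Neither measured step touches that nitrogen, so both bear on this change only indirectly. They show that this assay stayed within the scatter across changes elsewhere in the molecule. Within the data shown here, no measured compound carries anything but hydrogen at this place, so the direction remains open and no step beyond the scatter is expected. The expected size is a 1.2-fold higher number from compound 2 to compound 4 (0.08 log units; within the scatter), an estimate only. For compound 4 the estimated value is 2500 nM, with an expected range of 1000 nM to 6000 nM.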

Compound 4, half-maximal inhibitory concentration: 29100 nM
Compound 4: middle estimate off by 12-fold (1.07 log units), on the low side, outside the stated range (above it).
By their numbers in this assay, from the lowest: compounds 1, 2 and 3 (each within the scatter of the next, the first and the last beyond it); then compound 4.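

Methyl in place of hydrogen on the amine nitrogen in the ring is the first change in this series whose step lies beyond the scatter: in this assay it reads a 14-fold higher number from compound 2 to compound 4 (1.14 log units; beyond the scatter). The two earlier steps, at the aryl group and in the chain, stayed within the scatter, so they gave no sign of how much this nitrogen matters; among the steps shown, this is the one place where a single change makes a large difference, and compound 4 is the weakest inhibitor of the four. The result also shows that the hydrogen on this nitrogen cannot be exchanged for methyl without a large loss in this series, at least with the 4-acetamidophenyl group and the hexadecyl chain of compound 2 in place. Nothing at hand shows why the number rises so far at this nitrogen, or whether the loss of the hydrogen or the presence of the methyl is what counts.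

An ethyl or an acetyl group on this nitrogen would show whether the loss grows with the size of the group or is already complete with methyl. Going by these compounds, it also remains open whether the same methyl has a step of this size with the 3,4-dimethoxyphenyl group of compound 1 or the unsaturated chain of compound 3.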